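Swapping a thiophene for a pyrazole on a nucleoside core

The compounds below may be only part of what the source reports. "The series", "measured", "known", "first", "only" and "open" are said of these compounds alone.

Three nucleoside analogues share a fused two-ring core carrying a sugar and one variable aromatic group. Compound 1 `Cn1nccc1-c1ncnc2c1ncn2C1O[C@H](CO)[C@@H](O)[C@H]1O` carries a methylated pyrazole, while compound 2 `Cc1csc(-c2ncnc3c2ncn3C2O[C@H](CO)[C@@H](O)[C@H]2O)c1` carries a 4-methylthiophen-2-yl group. In a functional assay on CCRF-CEM cells (Homo sapiens) for inhibition (a higher number here means a weaker inhibitor, a lower number a stronger inhibitor), compound 1 is reported as "not active" (no number reported) and no number is given for it. In this assay, within the data shown here, compound 2 gives 2900 nM, the only number in this set, so there is no second value to rank it against.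

Compound 3 `OC[C@H]1OC(n2cnc3c(-c4cc[nH]n4)ncnc32)[C@H](O)[C@@H]1O` has not yet been measured. It differs from compound 2 in one place: 1H-pyrazol-3-yl in place of 4-methylthiophen-2-yl on an aromatic carbon. Among the measured compounds shown here, no measured pair shows what such a swap does on this core, so the direction of the step can only be guessed. Compound 3 is expected to be weaker than compound 2 because the other pyrazole-bearing member compound 1 gave "not active" (no number reported). The step is expected to be a 3.1-fold higher number from compound 2 to compound 3 (0.49 log units; beyond the scatter). For compound 3 the expected value in this assay is 9000 nM, with a range from 2500 nM to 35000 nM.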

Compound 3, half-maximal inhibitory concentration: 750 nM
Beside the measured number, compound 3's estimate is 12-fold (1.08 log units) above it; measured number below the stated range.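

In this assay, replacing the 4-methylthiophen-2-yl group with 1H-pyrazol-3-yl gives a 3.9-fold lower number from compound 2 to compound 3 (0.59 log units; beyond the scatter), so this aromatic carbon on the shared core accepts a pyrazole and the compound still gives a measurable, somewhat stronger inhibition. A pyrazole at this place therefore does not by itself abolish activity: compound 3 has a number, whereas compound 1, with its methylated pyrazole, is reported as "not active" (no number reported) in the same assay, so the form of the pyrazole seems to matter. Nothing available here explains the gain in strength or the contrast between the two pyrazoles.

The step changes several things at once, removing the sulfur and the methyl group and bringing in two ring nitrogens and a hydrogen-bond donor, so these compounds cannot show which of those changes counts. Also open, from the compounds shown here alone, is how this position would respond to a different kind of group, such as a plain phenyl ring, an amine or a carboxylic acid, or to a methyl group placed on the carbon atoms of the 1H-pyrazol-3-yl ring.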